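The compounds below may be only part of what the source reports. "The series", "measured", "known", "first", "only" and "open" are said of these compounds alone.

Compound 1 `CCS(=O)(=O)Nc1cc(-c2ccc3ncnc(Nc4cccc(F)c4)c3c2)cnc1OC`: 3940 nM in a functional assay on HCT-116 cells (Homo sapiens) for cytotoxicity, read by sulforhodamine B assay, with a stated time of 72 h; a higher number here means a weaker inhibitor, a lower number a stronger inhibitor
Compound 2 `CCS(=O)(=O)Nc1cc(-c2ccc3ncnc(Nc4ccc(OC)c(Cl)c4)c3c2)cnc1OC`: 5620 nM in this assay

Among the two numbers shown, compound 2 has the highest, and its nearest neighbour is compound 1, which lies within the scatter of it. Going by the values given here, the only measured step bearing on the change of the aryl group on the nitrogen is a 1.4-fold higher number from compound 1 to compound 2 (0.15 log units; within the scatter), which did not move the number beyond the scatter. Compound 3 `CCS(=O)(=O)Nc1cc(-c2ccc3ncnc(Nc4ccc(C(=O)OC)c(OC)c4)c3c2)cnc1OC` carries a further change at that same position: 3-methoxy-4-(methoxycarbonyl)phenyl in place of 3-chloro-4-methoxyphenyl on a nitrogen on an aromatic ring. Among the compounds with values here, no measured compound holds a 3-methoxy-4-(methoxycarbonyl)phenyl group, so the effect of this larger group is not covered by the data. Within the data shown here, on the single step that exists, the expected step of a 1.2-fold higher number from compound 2 to compound 3 (0.06 log units; within the scatter) is none beyond the scatter, with a wide range to reflect the absence of closer comparisons. Compound 3 is therefore estimated at 6500 nM in this assay, expected between 2000 nM and 20000 nM.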

Compound 3, half-maximal inhibitory concentration: 1690 nM
For compound 3 the middle estimate is 3.8-fold (0.59 log units) above the measured one; measured number outside the range, below it.
By their numbers in this assay, from the lowest: compound 3; then compounds 1 and 2 (each within the scatter of the next).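

In this assay, the aryl group on the nitrogen proves able to shift the number: 3-methoxy-4-(methoxycarbonyl)phenyl gives a 3.3-fold lower number from compound 2 to compound 3 (0.52 log units; beyond the scatter) and also a 2.3-fold lower number from compound 1 to compound 3 (0.37 log units; beyond the scatter). The earlier exchange of 3-fluorophenyl for 3-chloro-4-methoxyphenyl had stayed within the scatter, so this is the first change at this position shown to go beyond it, though both new steps are modest. No measurement at hand explains why this group lowers the number.

The compounds shown leave open whether the methoxy or the methoxycarbonyl part of the new group accounts for the step, as the two enter together. Going by these compounds, it also remains open whether a carboxylic acid or a primary amide in place of the methoxycarbonyl would keep the lower number.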